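A few compounds are considered here, and "the series" means these few. Any claim that something is new, unique, unknown or untested is made for them only; others in the source may bear on it.

Measured so far in a functional assay on PC-3 cells (Homo sapiens) for inhibition, read by sulforhodamine B assay, with a stated time of 48 h, tested at 50 uM; a lower number here means less inhibition of growth, a higher number more inhibition of growth at the concentration tested:
- compound 1 `COc1cc(/C=C/C(=O)/C=C/c2cccs2)ccc1OCc1cn(CCOc2cc(=O)oc3ccccc23)nn1`: 12%
- compound 2 `COc1ccc(/C=C/C(=O)/C=C/c2ccc(OCc3cn(CCOc4cc(=O)oc5ccccc45)nn3)c(OC)c2)cc1OC`: 19%
- compound 3 `COc1cc(/C=C/C(=O)/C=C/c2ccco2)ccc1OCc1cn(CCOc2cc(=O)oc3ccccc23)nn1`: 14%

At 14%, compound 3 lies within the scatter of both other compounds, so the series shows no order yet. Compound 4 `COc1ccccc1/C=C/C(=O)/C=C/c1ccc(OCc2cn(CCOc3cc(=O)oc4ccccc34)nn2)c(OC)c1` carries 2-methoxyphenyl in place of furan-2-yl on a double-bonded chain carbon bound to a double-bonded chain carbon. All measured exchanges at this place bear on it: a number 7 percentage points higher from compound 1 to compound 2 (within the scatter), a number 2 percentage points higher from compound 1 to compound 3 (within the scatter) and a number 5 percentage points lower from compound 2 to compound 3 (within the scatter). The last is the closest, as furan-2-yl enters in place of 3,4-dimethoxyphenyl. All three stay within the scatter, so no step beyond the scatter is expected in this assay. The expected step is a number 3 percentage points higher from compound 3 to compound 4 (within the scatter). For compound 4 the estimate is 17%, with an expected range of 7% to 29%.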

Compound 4, percent growth inhibition at one concentration: 11%
Beside the measured number, compound 4's estimate is 6 percentage points above it; measured number inside the range.
By their numbers in this assay, from the lowest: compounds 4, 1, 3 and 2 (each within the scatter of the next).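

With 2-methoxyphenyl on this double-bonded chain carbon, this assay gives a number 3 percentage points lower from compound 3 to compound 4 (within the scatter); the other two exchanges give a number 8 percentage points lower from compound 2 to compound 4 (within the scatter) and a number 1 percentage points lower from compound 1 to compound 4 (within the scatter). For the compounds shown here, all three steps stay within the scatter, so this six-membered aromatic ring of carbon only, with its single methoxy group, is not told apart from furan-2-yl, thiophen-2-yl or 3,4-dimethoxyphenyl. No data on the cause are at hand. Open, on these data alone, is whether any group at this place leaves the scatter, for instance an amine or a carboxylic acid in place of the aromatic ring.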